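The source may report more compounds than this note shows. Statements on the series, on what has been measured and on what is new or still open speak of the compounds shown alone.

Measured so far:
compound 1 `CCOc1ccc(NC(=O)Nc2cc(C(C)(C)C)nn2-c2ccccc2)cc1` gives 0.8 degrees C
compound 2 `Cc1ccc(F)cc1NC(=O)Nc1cc(C(C)(C)C)nn1-c1ccccc1` gives 4.1 degrees C

In an assay on isolated protein for inhibition of serine/threonine-protein kinase 10 (Homo sapiens), read by thermal shift assay, tested at 10 uM (on this read-out higher numbers stand for stronger stabilisation of the target against heat and lower numbers for weaker stabilisation of the target), compound 2 stands highest of the two, with compound 1 the nearer and lower number; the step of a number 3.3 degrees C higher from compound 1 to compound 2 (beyond the scatter) lies beyond the scatter. Compound 3 `CC(C)(C)c1cc(NC(=O)Nc2ccc(F)c(F)c2)n(-c2ccccc2)n1` differs from compound 2 by 3,4-difluorophenyl in place of 5-fluoro-2-methylphenyl on an amide-type nitrogen. Among the compounds with values here, the only measured step bearing on this change is a number 3.3 degrees C higher from compound 1 to compound 2 (beyond the scatter), which shows that exchanging the aryl group on the amide-type nitrogen can move the shift modestly; its direction for this new aryl is not fixed by the data. Compound 3 is therefore expected to give 2.5 degrees C, in a range from 0.5 degrees C to 4.5 degrees C. The expected step is a number 1.6 degrees C lower from compound 2 to compound 3 (beyond the scatter).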

Compound 3, shift of the target's melting temperature: 3.4 degrees C
Compound 3: middle estimate off by 0.90 degrees C, on the low side, and the stated range covers the measured number.
By their numbers in this assay, from the lowest: compound 1; then compounds 3 and 2 (each within the scatter of the next).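

In this assay, 3,4-difluorophenyl and 5-fluoro-2-methylphenyl on the amide-type nitrogen cannot be told apart, with a step of a number 0.70 degrees C lower from compound 2 to compound 3 (within the scatter), so the methyl group is not needed to keep the number up. The step of a number 2.6 degrees C higher from compound 1 to compound 3 (beyond the scatter) shows that a second replacement of 4-ethoxyphenyl also gives a higher number. No available evidence accounts for these numbers.

The compounds shown leave open whether unsubstituted phenyl would match the fluorinated rings. They also leave open how a pyridine ring or a carboxylic acid on the aryl group would read.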